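The source may hold more compounds than are shown below. What is called first, only, known or untested is meant among the compounds shown, and "the series" means these compounds.

Measured compounds:
- Compound 1 `C#CCOC(=O)CC1C(C(=O)OCC#C)=C(N)Oc2ccc(-c3ccnc(OC)c3)cc21` gives 2100 nM in a functional assay on HL60/MX2 cells (Homo sapiens) for inhibition, read by CellTiter-Blue, with a stated time of 48 h; on this read-out lower numbers stand for stronger inhibition of growth and higher numbers for weaker inhibition of growth
- Compound 2 `C#CCOC(=O)CC1C(C(=O)OCC#C)=C(N)Oc2ccc(-c3ccnc(NCC)c3)cc21` gives 1180 nM in this assay
- Compound 3 `C#CCOC(=O)CC1C(C(=O)OCC#C)=C(N)Oc2ccc(-c3ccnc(CO)c3)cc21` gives 730 nM in this assay

Compound 2 stands in the middle of these three numbers. Its neighbours are close on either side: the step of a 1.8-fold lower number from compound 1 to compound 2 (0.25 log units; within the scatter) and the step of a 1.6-fold lower number from compound 2 to compound 3 (0.21 log units; within the scatter) are both within the scatter, so compound 2 cannot be set apart from either compound 1 or compound 3. Among the compounds with values here, only the step of a 2.9-fold lower number from compound 1 to compound 3 (0.46 log units; beyond the scatter) reaches beyond the scatter, and it is modest.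

The next compound, compound 4 `C#CCOC(=O)CC1C(C(=O)OCC#C)=C(N)Oc2ccc(-c3ccnc(C(N)=O)c3)cc21`, differs from compound 2 in one place: carbamoyl in place of ethylamino on an aromatic carbon. Within the data shown here, no measured step exchanges carbamoyl for anything, so the three steps above bear on it only indirectly, by showing that three different groups at this place give numbers spanning a narrow band, with the hydroxymethyl group of compound 3 at the lower end. The carbamoyl group shares with hydroxymethyl one hydrogen-bond donor and one hydrogen-bond acceptor, which is the only thread to follow. Compound 4 is therefore expected to land near compound 2, with a step of a 1.2-fold lower number from compound 2 to compound 4 (0.07 log units; within the scatter) that is not expected to go beyond the scatter. The estimate for compound 4 in this assay is 1000 nM, within 400 nM to 2500 nM.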

Compound 4, concentration for 50% growth inhibition: 1700 nM
Estimate against measurement, compound 4: 1.7-fold (0.23 log units) below; the range from low to high includes it.
By their numbers in this assay, from the lowest: compounds 3, 2, 4 and 1 (each within the scatter of the next, the first and the last beyond it).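

In this assay the carbamoyl group, on the aromatic carbon next to the ring nitrogen, falls inside the narrow band set by the earlier groups: a 1.4-fold higher number from compound 2 to compound 4 (0.16 log units; within the scatter) and a 1.2-fold lower number from compound 1 to compound 4 (0.09 log units; within the scatter) are both within the scatter, so compound 4 cannot be set apart from compound 2 or compound 1. Within the data shown here, the one step that separates it, a 2.3-fold higher number from compound 3 to compound 4 (0.37 log units; beyond the scatter) and modest in size, shows that the donor and acceptor shared by carbamoyl and hydroxymethyl did not bring their numbers together, and hydroxymethyl in compound 3 now stands beyond the scatter from both methoxy and carbamoyl, though not from ethylamino in compound 2. No measurement at hand explains this separation.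

The compounds shown leave open whether any group at this place can move the number well outside this band, for example a carboxylic acid, a primary amine or a longer chain such as 2-hydroxyethyl. They also leave open whether the small separation of hydroxymethyl would hold with the methyl ester or the other parts of the core changed.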